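This account rests on a few compounds, and the source may have more. Where it says the series, first, only, none or still open, it means among the compounds named here.

In a functional assay on MOLT-4 cells (Homo sapiens) for antiproliferative activity, with a stated time of 48 h (on this read-out lower numbers stand for stronger inhibition and higher numbers for weaker inhibition), compound 3 (`Nc1ccc(/C=C/C(=O)c2ccc(Cl)cc2)cc1`) gives 7800 nM, the second highest of the three numbers. Compound 2 (`Nc1ccc(/C=C/C(=O)c2ccc(F)cc2)cc1`) gives 12000 nM, within the scatter of compound 3. Compound 1 (`C=C(Br)C(=O)Nc1ccc(/C=C/C(=O)c2ccc(Br)cc2)cc1`) gives 680 nM, well below both. Compound 4 (`Nc1ccc(/C=C/C(=O)c2ccc(Br)cc2)cc1`) differs from compound 3 by bromo in place of chloro on an aromatic carbon. Among the measured compounds shown here, the one measured step of this kind, chloro in place of fluoro, is a 1.5-fold lower number from compound 2 to compound 3 (0.19 log units; within the scatter), which stays within the scatter. Compound 1 also carries bromo but differs from compound 4 by a further group, so it says little about this step. No change beyond the scatter is therefore expected in this assay. The expected step is a 1.1-fold lower number from compound 3 to compound 4 (0.05 log units; within the scatter). The estimated value for compound 4 is 7000 nM, with an expected range of 3500 nM to 14000 nM.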

Compound 4, half-maximal inhibitory concentration: 10000 nM
Compound 4: middle estimate off by 1.4-fold (0.15 log units), on the low side, within the range that was stated.
By their numbers in this assay, from the lowest: compound 1; then compounds 3, 4 and 2 (each within the scatter of the next).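

In this assay the change from chloro to bromo on the aromatic carbon gives (a 1.3-fold higher number from compound 3 to compound 4 (0.11 log units; within the scatter)) and the change from fluoro to bromo gives (a 1.2-fold lower number from compound 2 to compound 4 (0.08 log units; within the scatter)), so these three halogens do not separate at this position. The large change lies at the nitrogen instead, where hydrogen in place of (1-bromoethenyl)carbonyl gives (a 15-fold higher number from compound 1 to compound 4 (1.17 log units; beyond the scatter)). Nothing available explains either result. As far as these compounds go, whether methoxy or a nitrile at this position would move the number remains open. So does whether (1-bromoethenyl)carbonyl on the nitrogen has the same effect with chloro or fluoro on the ring.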